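Adding Chloro to the Fluorophenyl of Compound 3

The compounds below may be only part of what the source reports. "The series", "measured", "known", "first", "only" and "open" are said of these compounds alone.

Compound 1, `Cn1ncc2c(NC(=O)NCc3cc(C(C)(C)C)nn3-c3cccc(Cl)c3)cccc21`, gives 0.4 nM in an assay on CHO-K1 cells for antagonist activity at transient receptor potential cation channel subfamily V member 1 (Homo sapiens), read by FLIPR and calcium flux, with a stated time of 6 min; a lower number here means a stronger inhibitor, a higher number a weaker inhibitor.
Compound 2, `Cn1ncc2c(NC(=O)NCc3cc(C(C)(C)C)nn3-c3cccc(C(F)(F)F)c3)cccc21`, gives 0.6 nM in this assay.
Compound 3, `Cn1ncc2c(NC(=O)NCc3cc(C(C)(C)C)nn3-c3ccc(F)cc3)cccc21`, gives 4.5 nM in this assay.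

Compound 3 has the highest number of the three measured compounds, and its gap to each of the other two lies beyond the scatter, so it is the weakest inhibitor shown here. Compound 4, `Cn1ncc2c(NC(=O)NCc3cc(C(C)(C)C)nn3-c3ccc(F)c(Cl)c3)cccc21`, differs from compound 3 by chloro in place of hydrogen on an aromatic carbon.

Going by the values given here, two measured steps bear on this change: an 11-fold higher number from compound 1 to compound 3 (1.05 log units; beyond the scatter) and a 7.5-fold higher number from compound 2 to compound 3 (0.88 log units; beyond the scatter). Read backwards, both show that a phenyl bearing chloro or trifluoromethyl gives a clearly lower number than 4-fluorophenyl, with compound 1 and compound 2 close to each other. Compound 4 keeps the fluoro of compound 3 and gains a chloro, so a step back down of similar size is expected: a 5.6-fold lower number from compound 3 to compound 4 (0.75 log units; beyond the scatter). Compound 4 is therefore estimated at 0.8 nM in this assay, with an expected range from 0.3 nM to 2.5 nM.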

Compound 4, inhibition constant: 0.6 nM
Compound 4: the middle estimate sits 1.3-fold (0.12 log units) above what was measured, within the range that was stated.
By their numbers in this assay, from the lowest: compounds 1, 2 and 4 (each within the scatter of the next); then compound 3.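

In this assay, adding a single chloro to the 4-fluorophenyl ring gives a 7.5-fold lower number from compound 3 to compound 4 (0.88 log units; beyond the scatter), so this one atom accounts for a step that earlier could be seen only when the whole aryl group was exchanged. The fluoro group does not stand in the way of this gain: the 3-chloro-4-fluorophenyl group gives no change at the digits printed from compound 2 to compound 4 (within the scatter), and fluoro in place of hydrogen on the 3-chlorophenyl ring gives a 1.5-fold higher number from compound 1 to compound 4 (0.18 log units; within the scatter), both within the scatter. Nothing given here explains why chloro at this place lowers the number.

From the compounds shown here alone, whether a methyl, a methoxy, a nitrile or an amine at this place would match chloro remains open. So does whether the chloro step would keep its size with a group other than tert-butyl on the shared core.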